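The source may hold more compounds than are shown below. What is called first, only, known or untested is meant among the compounds shown, and "the series" means these compounds.

Compound 1 `C[C@@H](Cn1ccc(-c2ccc(C#N)c(Cl)c2)n1)NC(=O)c1ccccc1F`: in an ADME assay on PC-3 cells (Homo sapiens) for cytotoxicity, read by CCK-8 assay, with a stated time of 6 days (on this read-out higher numbers stand for weaker inhibition and lower numbers for stronger inhibition), compound 1 gives > 30000 nM, a limit of the assay rather than a number.
Compound 2 `C[C@@H](Cn1ccc(-c2ccc(C#N)c(Cl)c2)n1)Nc1ncnc2nc[nH]c12`: in this assay compound 2 gives 14100 nM.

Compound 2 thus holds the only number shown in this assay; the other value is a limit (the limit of > 30000 nM in this assay, at which 1 of the 2 values shown sits). For the measured compounds named here, the single measured step, an at least 2.1-fold lower number from compound 1 to compound 2 (0.32 log units; beyond the scatter), concerns the group on the amine nitrogen, where the fluorinated benzamide of compound 1 gives way to the fused bicyclic group of compound 2.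

Compound 3 `C[C@@H](Cn1ccc(-c2ccc(C#N)c(Cl)c2)n1)Nc1nc(Cl)nc2nc[nH]c12` differs from compound 2 by chloro in place of hydrogen on an aromatic carbon. Going by the values given here, no measured step touches this ring, so the step from compound 1 to compound 2 offers no direct guide to it. The expectation for compound 3 in this assay is therefore a step no larger than the scatter, in either direction. Compound 3 is accordingly estimated at 12000 nM, within 5000 nM to 30000 nM. The expected step is a 1.2-fold lower number from compound 2 to compound 3 (0.07 log units; within the scatter).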

Compound 3, half-maximal inhibitory concentration: > 30000 nM
Compound 3: no number, only a limit; the forecaster's own chance of this, stated with the estimate: 20%; middle value at least 2.5-fold (0.39 log units) away from the limit.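

Chloro in place of hydrogen on an aromatic carbon, between two ring nitrogen atoms, is the first change shown at this position, and it gives an at least 2.1-fold higher number from compound 2 to compound 3 (0.32 log units; beyond the scatter). The earlier step concerned the whole group on the amine nitrogen, whereas this one shows that, with that group held constant, a single added chlorine atom on the six-membered aromatic ring is enough to move the read-out beyond the scatter, toward weaker inhibition. In this assay compound 3 gives > 30000 nM, which is a limit of the assay and not a number, so the step has a lower bound but no known size, and compound 2 remains the only compound with a measured number here: the limit of > 30000 nM in this assay, at which 2 of the 3 values shown sit.

The compounds shown leave open whether this shift belongs to chloro in particular or would also follow from fluoro, methyl, methoxy or an amine on the same aromatic carbon. They also leave open how a substituent elsewhere on the fused system of two rings would change the number of compound 2.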